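Swapping the methoxyphenyl arm for a naphthyl in a pyrazole-oxindole series

The source may report more compounds than this note shows. Statements on the series, on what has been measured and on what is new or still open speak of the compounds shown alone.

Measured so far:
compound 1, `COc1ccc(-c2cc(-c3ccc(Cl)cc3)n(C3C(=O)Nc4ccc(Br)cc43)n2)cc1`: 9750 nM
compound 2, `COc1ccc(-c2cc(-c3ccc(Cl)cc3)n(C3C(=O)Nc4ccc(Cl)cc43)n2)cc1`: 3680 nM
compound 3, `CN(C)c1ccc(-c2cc(-c3ccccc3)nn2C2C(=O)Nc3ccccc32)cc1`: 18900 nM

All three were tested in a functional assay on cells (Cancer cell lines, Homo sapiens) for cytotoxicity, read by sulforhodamine B assay, with a stated time of 48 h; a lower number here means a stronger inhibitor of growth, a higher number a weaker inhibitor of growth. On these numbers compound 1 stands second highest of the three. Its nearest neighbour is compound 3, whose value lies within the usual scatter of it, so the two cannot be ordered. Compound 2 lies clearly lower: a 2.6-fold lower number from compound 1 to compound 2 (0.42 log units; beyond the scatter), a modest but real step.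

Compound 4, `O=C1Nc2ccc(Br)cc2C1n1nc(-c2ccc3ccccc3c2)cc1-c1ccc(Cl)cc1`, keeps the core of compound 1 and changes one arm: naphthalen-2-yl in place of 4-methoxyphenyl on an aromatic carbon. Going by the values given here, no measured pair shows this change. Among the compounds with values here, the only single-point step on record, from compound 1 to compound 2, concerns a halogen on the oxindole part and says nothing about the aryl arm at the pyrazole. Compound 3 differs from compound 1 in several places at once, so it cannot isolate this change either. With nothing to anchor a direction, no step beyond the scatter is expected, a 1.2-fold lower number from compound 1 to compound 4 (0.09 log units; within the scatter), and the uncertainty is wide. Compound 4 is thus estimated at 8000 nM, with a plausible range from 2500 nM to 25000 nM.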

Compound 4, concentration for 50% growth inhibition: 3090 nM
For compound 4 the middle estimate is 2.6-fold (0.41 log units) above the measured one; measured number inside the range.
By their numbers in this assay, from the lowest: compounds 4 and 2 (each within the scatter of the next); then compounds 1 and 3 (each within the scatter of the next).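

Going by these compounds alone, this gives the first direct reading of the aryl arm on the aromatic carbon of the five-membered ring with 2 nitrogen: in this assay, naphthalen-2-yl in place of 4-methoxyphenyl gives a 3.2-fold lower number from compound 1 to compound 4 (0.50 log units; beyond the scatter). Growth inhibition therefore does not depend on the arm's oxygen, its only hydrogen-bond acceptor, and this position accepts a second six-membered aromatic ring with a modest gain. No measurement here explains that gain.

The change removes the oxygen and adds a ring at once, so the two contributions cannot be separated; a 4-methylphenyl or naphthalen-1-yl arm at this position would help to tell them apart. On these data alone, it also remains open whether an arm carrying an amine or a carboxylic acid would be accepted here, and whether chloro in place of bromo would lower the number further with naphthalen-2-yl present.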